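The compounds below may be only part of what the source reports. "The series", "measured", "known", "first", "only" and "open" are said of these compounds alone.

Values in a functional assay on SEM cells (Homo sapiens) for cytotoxicity, with a stated time of 72 h; on this read-out higher numbers stand for an effect only at larger amounts of compound and lower numbers for an effect already at smaller amounts:
- compound 1 `C=C[C@@](C)(/C=C/c1ccc(O)c(/C=C/C(=O)OCC)c1)CCC=C(C)C`: > 36600 nM
- compound 2 `C=C[C@@](C)(/C=C/c1ccc(O)c(/C=C/C(=O)OCc2ccccc2)c1)CCC=C(C)C`: > 36600 nM

Compound 1 carries a limit and not a number. Compound 2, at > 36600 nM, also carries only a limit, so its place in the series cannot be read beyond that. Both measured compounds sit at the same ceiling: the limit of > 36600 nM in this assay, at which 2 of the 2 values shown sit.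

The next structure is compound 3 `C=C[C@@](C)(/C=C/c1ccc(O)c(/C=C/C(=O)O)c1)CCC=C(C)C`. Its difference from compound 2 is hydrogen in place of benzyl on an oxygen next to a carbonyl group, that is, benzyloxycarbonyl to carboxy. Within the data shown here, the only measured step is a step that the two limits leave unreadable from compound 1 to compound 2. That step exchanges one ester group for another and gives no size to carry over. Among the measured compounds shown here, no measured compound carries the free carboxy group, so the data hold no direct precedent for this change.

With no readable step to draw on, no clear shift in this assay is expected in either direction, and another limit is the likeliest report. The expected step is a step that the limit leaves unreadable from compound 2 to compound 3. For compound 3 the estimated value is 40000 nM, with an expected range of 15000 nM to 100000 nM.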

Compound 3, half-maximal effective concentration: > 36600 nM
Compound 3 ended at the assay's limit; the forecaster's own chance of this, stated with the estimate: 85%; the middle value lies beyond the limit too.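

No step among compound 1, compound 2 and compound 3 can be read in this assay, since each value is a limit and not a number: the limit of > 36600 nM in this assay, at which 3 of the 3 values shown sit.

The compounds shown leave open whether the ethyl ester, the benzyl ester and the free carboxy group differ at all in this assay.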